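Changing the amine end of an amide side chain

The compounds below may be only part of what the source reports. "The series", "measured", "known", "first", "only" and "open" are said of these compounds alone.

In a functional assay on PC-3 cells (Homo sapiens), read by MTT assay, with a stated time of 48 h (a lower number here means a stronger inhibitor, a higher number a weaker inhibitor), compound 1 `CCOC(=O)CN(C)C(=O)c1ccc(C(CC)(CC)c2ccc(OCC(O)C(C)(C)C)c(C)c2)n1CC` gives 25500 nM and compound 2 `CCN(CC)CCNC(=O)c1ccc(C(CC)(CC)c2ccc(OCC(O)C(C)(C)C)c(C)c2)n1CC` gives 220 nM as the lower of the two numbers. For the measured compounds named here, the only measured step is large: a 120-fold lower number from compound 1 to compound 2 (2.06 log units; beyond the scatter) when (2-(diethylamino)ethyl)amino takes the place of ((ethoxycarbonyl)methyl)(methyl)amino on a carbonyl carbon. Compound 3 `CCn1c(C(=O)NCCCN(C)C)ccc1C(CC)(CC)c1ccc(OCC(O)C(C)(C)C)c(C)c1` departs from compound 2 by a smaller edit, (dimethylamino)methyl in place of diethylamino on a saturated chain carbon, two bonds along the chain from an amide-type nitrogen on a saturated chain carbon, which turns (2-(diethylamino)ethyl)amino into (3-(dimethylamino)propyl)amino. Going by the values given here, no measured pair tests this edit, and the large step replaced a different group, so it sets no size for this one. In this assay the estimated step is a 1.6-fold higher number from compound 2 to compound 3 (0.20 log units; within the scatter) and none beyond the scatter is expected, though the uncertainty is wide. Compound 3 is expected at 350 nM with a range of 100 nM to 1800 nM in this estimate.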

Compound 3, half-maximal inhibitory concentration: 3100 nM
For compound 3 the middle estimate is 8.9-fold (0.95 log units) below the measured one; measured number above the stated range.
By their numbers in this assay, from the lowest: compound 2; then compound 3; then compound 1.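

In this assay the amine end of the side chain proves sensitive even to an edit that leaves the donor and acceptor counts unchanged: (dimethylamino)methyl in place of diethylamino gives a large loss (a 14-fold higher number from compound 2 to compound 3 (1.15 log units; beyond the scatter)). Compound 3 still keeps part of the gain over the ester side chain of compound 1 (an 8.2-fold lower number from compound 1 to compound 3 (0.92 log units; beyond the scatter)), though this modest step is much smaller than the large one to compound 2 (a 120-fold lower number from compound 1 to compound 2 (2.06 log units; beyond the scatter)). No evidence is available that accounts for the difference between compound 2 and compound 3.

This edit lengthens the chain and changes the amine ending together, so the compounds shown cannot say which of the two carries the loss. A (3-(diethylamino)propyl)amino or a (2-(dimethylamino)ethyl)amino side chain would separate them.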